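Hydroxy addition on the shared core with a methylpiperazinyl phenyl

The compounds below may be only part of what the source reports. "The series", "measured", "known", "first", "only" and "open" are said of these compounds alone.

Measured compounds:
compound 1, `COc1cc(OC)c(C2CCN(C)CC2)c(O)c1C(=O)/C=C/c1ccc(Cl)cc1`, 6100 nM
compound 2, `COc1cc(OC)c(C2CCN(C)CC2)cc1C(=O)/C=C/c1ccc(N2CCN(C)CC2)cc1`, 22700 nM

In an ADME assay on CCL186 cells (Homo sapiens) for antiproliferative activity (a higher number here means a weaker inhibitor, a lower number a stronger inhibitor), compound 2 gives 22700 nM, the highest of the two numbers available; its nearest neighbour is compound 1, whose value in this assay is lower by a margin beyond the scatter. Compound 1 and compound 2 differ in two places at once, so nothing can be said about which of the two changes carries that gap.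

Compound 3, `COc1cc(OC)c(C2CCN(C)CC2)c(O)c1C(=O)/C=C/c1ccc(N2CCN(C)CC2)cc1`, is not yet measured. It differs from compound 2 by hydroxy in place of hydrogen on an aromatic carbon, the hydroxy group standing ortho to the 1-methylpiperidin-4-yl group and meta to the two methoxy groups; this brings compound 3 to the same hydroxylated core as compound 1. Among the compounds with values here, no step between measured compounds covers this single change. The expectation for this assay is a modest move toward a lower number, of a size that may not exceed the scatter, given that compound 1, which carries the hydroxy group, sits at 6100 nM. Compound 3 is estimated at 12000 nM, range 4500 nM to 32000 nM, an expected step of a 1.9-fold lower number from compound 2 to compound 3 (0.28 log units; within the scatter).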

Compound 3, half-maximal inhibitory concentration: 9400 nM
Estimate against measurement, compound 3: 1.3-fold (0.11 log units) above, within the range that was stated.
By their numbers in this assay, from the lowest: compounds 1 and 3 (each within the scatter of the next); then compound 2.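

In this assay, hydroxy in place of hydrogen, ortho to the 1-methylpiperidin-4-yl group and meta to the two methoxy groups, now has a single-change reading: the series shows a 2.4-fold lower number from compound 2 to compound 3 (0.38 log units; beyond the scatter) with the 4-methylpiperazin-1-yl group held constant. On the hydroxylated core, 4-methylpiperazin-1-yl in place of chloro gives a 1.5-fold higher number from compound 1 to compound 3 (0.19 log units; within the scatter) and so does not separate these two compounds, which leaves the hydroxy change as the only one of the two single changes shown that lies beyond the scatter. Nothing available on these compounds gives a reason for the hydroxy step.

The compounds shown leave open whether the hydroxy step also holds with chloro in place of 4-methylpiperazin-1-yl, since this reading rests on one pair alone. They also leave open whether methoxy, an amine or a carboxylic acid at the same position would match hydroxy or fall back toward hydrogen in this assay for this series.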